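Thiocarbamate benzamides: amine swap on the thiocarbonyl carbon

A few compounds are considered here, and "the series" means these few. Any claim that something is new, unique, unknown or untested is made for them only; others in the source may bear on it.

Measured compounds in a functional assay on HeLa cells (Homo sapiens) for antiproliferative activity, read by CCK-8 assay, with a stated time of 72 h, tested at 8 uM; a higher number here means a stronger effect of the compound at the concentration tested, a lower number a weaker effect:
compound 1 `CC1CCCCN1C(=S)SCc1ccc(C(=O)Nc2ccccc2N)cc1`: 76.3%
compound 2 `CCN(Cc1ccncc1)C(=S)SCc1ccc(C(=O)Nc2ccccc2N)cc1`: 77.7%
compound 3 `Nc1ccccc1NC(=O)c1ccc(CSC(=S)N2CCc3cc(Cl)ccc32)cc1`: 65.1%

Compound 3 stands lowest of the three numbers. Its nearest neighbour is compound 1, the step of a number 11.2 percentage points lower from compound 1 to compound 3 (beyond the scatter) lying beyond the scatter; the furthest is compound 2, with a number 12.6 percentage points lower from compound 2 to compound 3 (beyond the scatter) also beyond the scatter. Between compound 1 and compound 2 the step of a number 1.4 percentage points higher from compound 1 to compound 2 (within the scatter) is within the scatter, so the two smaller amines on the thiocarbonyl carbon give the same read-out.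

Compound 4 `Nc1ccccc1NC(=O)c1ccc(CSC(=S)N2CCCC2)cc1` has not been measured in this assay. Its change from compound 3:
pyrrolidin-1-yl in place of 5-chloro-2,3-dihydro-1H-indol-1-yl on a thiocarbonyl carbon

For the measured compounds named here, the steps that bear on this change are the two that put 5-chloro-2,3-dihydro-1H-indol-1-yl in place of a smaller amine, both modest and both beyond the scatter. Pyrrolidin-1-yl is a single five-membered non-aromatic ring with 1 hetero atom, closer in count to 2-methylpiperidin-1-yl than to the group it replaces, so a step back upward of about that size is expected: a number 8.9 percentage points higher from compound 3 to compound 4 (within the scatter). Compound 4 is estimated at 74% in this assay, expected to fall between 62% and 84%. Going by the values given here, no compound bearing pyrrolidin-1-yl has been measured, so the range is kept wide.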

Compound 4, a percentage reported as inhibition, at one concentration (the size of the read-out at that concentration, not a potency): 77.8%
The estimate for compound 4 lay 3.8 percentage points below the measured number; the range from low to high includes it.
By their numbers in this assay, from the lowest: compound 3; then compounds 1, 2 and 4 (each within the scatter of the next).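

In this assay the swap on the thiocarbonyl carbon gives a number 12.7 percentage points higher from compound 3 to compound 4 (beyond the scatter), so pyrrolidin-1-yl joins the amines that stand apart from 5-chloro-2,3-dihydro-1H-indol-1-yl. The steps of a number 0.1 percentage points higher from compound 2 to compound 4 (within the scatter) and a number 1.5 percentage points higher from compound 1 to compound 4 (within the scatter) place pyrrolidin-1-yl level with ethyl((pyridin-4-yl)methyl)amino and 2-methylpiperidin-1-yl, so three differently built amines give the same read-out here, with compound 3 the one exception. Nothing available bears on why compound 3 stands apart.

On these data alone, whether the chlorine or the fused aromatic ring goes with the lower number of compound 3 stays open, and unsubstituted 2,3-dihydro-1H-indol-1-yl would separate the two. Morpholin-4-yl would show whether a second ring hetero atom holds the read-out at this level.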